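A few compounds are considered here, and "the series" means these few. Any claim that something is new, unique, unknown or untested is made for them only; others in the source may bear on it.

Measured in a functional assay on MCF7 cells (Homo sapiens) for inhibition, read by MTT assay, with a stated time of 72 h; on this read-out lower numbers stand for stronger inhibition and higher numbers for weaker inhibition:
Compound 1 `Cc1csc(Sc2cc(C(F)(F)F)nc(SCc3ccc(C(F)(F)F)cc3)n2)n1`: 14500 nM
Compound 2 `FC(F)(F)c1ccc(CSc2nc(Sc3ncccn3)cc(C(F)(F)F)n2)cc1`: > 50000 nM (a limit of the assay, not a number)
Compound 3 `FC(F)(F)c1ccc(CSc2nc(Sc3ccccn3)cc(C(F)(F)F)n2)cc1`: 43200 nM

Compound 3 holds the higher of the two exact numbers in this assay, and compound 1 holds the lower. Exchanging the group on the sulfur has already shifted the read-out, with a 3.0-fold higher number from compound 1 to compound 3 (0.47 log units; beyond the scatter) and an at least 3.4-fold higher number from compound 1 to compound 2 (0.53 log units; beyond the scatter). Between the two six-membered groups there is an at least 1.1-fold lower number from compound 2 to compound 3 (0.06 log units; that floor lies within the scatter).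

Compound 4 `FC(F)(F)c1ccc(CSc2nc(Sc3nnnn3-c3ccccc3)cc(C(F)(F)F)n2)cc1` changes that same place, with 1-phenyl-1H-tetrazol-5-yl in place of pyridin-2-yl on a sulfur. Among the compounds with values here, the steps from compound 1 are the only guide to how far such an exchange can move the number, and they are modest. A modest fall is expected rather than a rise, because compound 3 already reads 43200 nM, close to the top of the measurable range. The expected change is a 1.7-fold lower number from compound 3 to compound 4 (0.24 log units; within the scatter). For compound 4 the estimated value is 25000 nM, with an expected range of 10000 nM to 50000 nM.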

Compound 4, half-maximal inhibitory concentration: 39500 nM
Compound 4: the middle estimate sits 1.6-fold (0.20 log units) below what was measured, and the stated range covers the measured number.
By their numbers in this assay, from the lowest: compound 1; then compounds 4 and 3 (each within the scatter of the next). At a limit, above all of these: compound 2.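

The larger 1-phenyl-1H-tetrazol-5-yl, which brings a five-membered aromatic ring with 4 hetero atoms and a six-membered aromatic ring of carbon only, leaves the read-out in this assay within the scatter of the pyridin-2-yl compound (a 1.1-fold lower number from compound 3 to compound 4 (0.04 log units; within the scatter)). The 4-methyl-1,3-thiazol-2-yl group of compound 1 still stands apart from it (a 2.7-fold higher number from compound 1 to compound 4 (0.44 log units; beyond the scatter)), so among the exact numbers a lower value remains confined to compound 1. Compound 2 remains a limit of the assay and not a number, and its step (an at least 1.2-fold lower number from compound 2 to compound 4 (0.10 log units; that floor lies within the scatter)) gives only a floor: the limit of > 50000 nM in this assay, at which 1 of the 4 values shown sits.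

All the groups shown on this sulfur are aromatic rings, so how an amine, a carboxylic acid or a longer alkyl chain would read there remains open. On these data alone, it also remains open whether any group at this place can take the number far below that of compound 1.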